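Swapping hexyl for cyclopentyl on a sulfonyl chain

The source may hold more compounds than are shown below. What is called first, only, known or untested is meant among the compounds shown, and "the series" means these compounds.

In a functional assay, read by fluorescence and spectrophotometry, with a stated time of 1 h (a lower number here means that less compound is needed, a higher number that more compound is needed for the effect), compound 3 `CCCCCCCS(=O)(=O)/C=C/c1ccc(O)c(O)c1` gives 7100 nM. Compound 1 `O=S(=O)(/C=C/c1ccc(O)c(O)c1)CC1CCC1` gives 8800 nM, and compound 2 `O=S(=O)(/C=C/c1ccc(O)c(O)c1)CC1CCCCO1` gives 10800 nM. Compound 3 therefore stands level with both, within the usual scatter of repeat measurements. Compound 4 `O=S(=O)(/C=C/c1ccc(O)c(O)c1)CC1CCCC1` carries cyclopentyl in place of hexyl on a saturated chain carbon bound to a sulfonyl sulfur. The measured steps that bear on this change alter the same group. They are a 1.2-fold lower number from compound 1 to compound 3 (0.09 log units; within the scatter) and a 1.5-fold lower number from compound 2 to compound 3 (0.18 log units; within the scatter), both within the scatter. No step beyond the scatter is thus expected in this assay. The estimated step is a 1.1-fold higher number from compound 3 to compound 4 (0.05 log units; within the scatter). For compound 4, the expected value is 8000 nM, with an estimated range of 4500 nM to 14000 nM.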

Compound 4, half-maximal effective concentration: 9400 nM
Estimate against measurement, compound 4: 1.2-fold (0.07 log units) below, within the range that was stated.
By their numbers in this assay, from the lowest: compounds 3, 1, 4 and 2 (each within the scatter of the next).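

Cyclopentyl on a saturated chain carbon bound to a sulfonyl sulfur stays level with all three earlier groups in this assay and so adds a five-membered carbon ring to the groups that read alike here. In place of hexyl it gives a 1.3-fold higher number from compound 3 to compound 4 (0.12 log units; within the scatter) and in place of oxan-2-yl it gives a 1.1-fold lower number from compound 2 to compound 4 (0.06 log units; within the scatter) while in place of cyclobutyl it gives a 1.1-fold higher number from compound 1 to compound 4 (0.03 log units; within the scatter) and so, among these four groups, neither ring nor open chain separates the compounds. Going by these compounds, whether an amine or a carboxylic acid at this position would move the number beyond the scatter stays open. No evidence here says why these four groups read alike.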